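The source may hold more compounds than are shown below. What is called first, only, known or untested is meant among the compounds shown, and "the series" means these compounds.

Among the measured compounds shown here, in a functional assay on DU-145 cells (Homo sapiens) for inhibition, read by trypan blue exclusion, with a stated time of 72 h (a lower number here means a stronger inhibitor, a higher number a weaker inhibitor), compound 1 `COc1ccc(S(=O)(=O)c2cc3cnc(Nc4ccc5[nH]ccc5c4)nc3n(C)c2=O)cc1` gives 500 nM, the lowest of the three numbers so far, which makes it the strongest inhibitor of the set. Compound 2 `COc1ccc(S(=O)(=O)c2cc3cnc(Nc4cccc5[nH]ccc45)nc3n(C)c2=O)cc1` gives 5000 nM and compound 3 `Cn1c(=O)c(S(=O)(=O)c2ccc(F)cc2F)cc2cnc(Nc3ccc4cc[nH]c4c3)nc21` gives 5000 nM. The next molecule, compound 4 `Cn1c(=O)c(S(=O)(=O)c2ccc(Br)cc2)cc2cnc(Nc3ccc4[nH]ccc4c3)nc21`, keeps the structure of compound 1 except for one substituent, with bromo in place of methoxy on an aromatic carbon. In other words, a (4-methoxyphenyl)sulfonyl becomes a (4-bromophenyl)sulfonyl. For the measured compounds named here, the only measured single change is a 10-fold higher number from compound 1 to compound 2 (1.00 log units; beyond the scatter). That step swaps 1H-indol-5-yl for 1H-indol-4-yl and leaves the methoxy untouched, so it says little about this substitution. Going by the values given here, no measured pair isolates this substituent, so a step within the usual scatter is the best expectation in this assay, with no firm direction. The estimated step is a 1.6-fold higher number from compound 1 to compound 4 (0.20 log units; within the scatter). For compound 4 the expected value is 800 nM, with an estimated range of 200 nM to 3000 nM.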

Compound 4, half-maximal inhibitory concentration: 5000 nM
Compound 4: middle estimate off by 6.3-fold (0.80 log units), on the low side; measured number outside the range, above it.
By their numbers in this assay, from the lowest: compound 1; then compounds 2, 3 and 4 (each within the scatter of the next).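

In this assay, among the compounds shown here, replacing 4-methoxyphenyl with 4-bromophenyl gives a 10-fold higher number from compound 1 to compound 4 (1.00 log units; beyond the scatter), so this substituent clearly matters, which no earlier pair could show. The step is the same size as a 10-fold higher number from compound 1 to compound 2 (1.00 log units; beyond the scatter), so on the core of compound 1 a change at this substituent counts for as much as moving the attachment point of the indole. The swap replaces two heavy atoms, including a hydrogen-bond acceptor, with a single bromine, but nothing measured here ties the result to any of these differences.

Only methoxy and bromo are shown at this place with the 1H-indol-5-yl group, so it stays open whether a hydroxyl, an ethoxy or an amine there would match compound 1 at 500 nM. Compound 3 differs from compound 1 in more than one place, so it cannot settle this.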